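Azetidinyl sulfonyl analogue of compound 1: clearance expectation

The compounds below may be only part of what the source reports. "The series", "measured", "known", "first", "only" and "open" are said of these compounds alone.

Among the measured compounds shown here, compound 1 `COc1cc(-c2nnc(S(=O)(=O)C3CCC3)[nH]2)ccc1-c1cnc(OCC(C)C)c(Cl)c1` gives 59 uL/min in an ADME assay on microsomes from liver (Homo sapiens) for metabolic stability (a lower number here means slower removal, a higher number faster removal of the compound), the higher of the two numbers so far; its fluoro analogue compound 2 `COc1cc(-c2nnc(S(=O)(=O)C3CCC3)[nH]2)c(F)cc1-c1cnc(OCC(C)C)c(Cl)c1` gives 16 uL/min, and the step of a 3.7-fold lower number from compound 1 to compound 2 (0.57 log units; beyond the scatter) is the only one measured. Compound 3 `COc1cc(-c2nnc(S(=O)(=O)N3CCC3)[nH]2)ccc1-c1cnc(OCC(C)C)c(Cl)c1` carries azetidin-1-yl in place of cyclobutyl on a sulfonyl sulfur. For the measured compounds named here, no measured step touches the sulfonyl substituent, so this change is unmapped; with no pointer in either direction, compound 3 is expected to land within the scatter of compound 1. For compound 3 the estimate is 55 uL/min (range 25 uL/min to 120 uL/min), meaning an expected step of a 1.1-fold lower number from compound 1 to compound 3 (0.03 log units; within the scatter).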

Compound 3, intrinsic clearance in a liver preparation (reported as CLH), per the amount of preparation that the assay uses: 38 uL/min
Beside the measured number, compound 3's estimate is 1.4-fold (0.16 log units) above it; measured number inside the range.
By their numbers in this assay, from the lowest: compound 2; then compounds 3 and 1 (each within the scatter of the next).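

Among the compounds shown here, this is the first reading at the sulfonyl substituent: in this assay, the step from cyclobutyl to azetidin-1-yl is a 1.6-fold lower number from compound 1 to compound 3 (0.19 log units; within the scatter). At this position, exchanging a ring carbon for nitrogen therefore gives no difference that can be told from the scatter, and only a 3.7-fold lower number from compound 1 to compound 2 (0.57 log units; beyond the scatter) remains a step beyond it. No available evidence bears on this result.

Still open, on these data alone, is whether a larger ring such as morpholine, or an open-chain dimethylamino group, on the sulfonyl sulfur would stay within the scatter. Also open, as far as these compounds go, is how azetidin-1-yl and fluoro behave together in one compound.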